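Notes on the ring-substituent swap from compound 3 to compound 4

A few compounds are considered here, and "the series" means these few. Any claim that something is new, unique, unknown or untested is made for them only; others in the source may bear on it.

Measured so far in an assay on HEK293 cells for inhibition of N-acylethanolamine-hydrolyzing acid amidase (Rattus norvegicus), read by LC-MS, with a stated time of 30 min; on this read-out lower numbers stand for stronger inhibition and higher numbers for weaker inhibition:
compound 1, `O=C(CCCCCc1cccc(Br)c1)N1CCOC1=O`, gives 430 nM.
compound 2, `O=C(CCCCCc1cccc(I)c1)N1CCOC1=O`, gives 3120 nM.
compound 3, `NC(=O)c1cccc(CCCCCC(=O)N2CCOC2=O)c1`, gives > 20000 nM, which is a limit of the assay and not a number.

Compound 3 therefore stands at the limit of > 20000 nM in this assay, at which 1 of the 3 values shown sits, and is the weakest of the three: the two steps leading to it, an at least 46-fold higher number from compound 1 to compound 3 (1.66 log units; beyond the scatter) and an at least 6.4-fold higher number from compound 2 to compound 3 (0.80 log units; beyond the scatter), both lie beyond the scatter. Between the two halogen compounds, the step of a 7.3-fold higher number from compound 1 to compound 2 (0.86 log units; beyond the scatter) is also beyond the scatter.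

Compound 4 is `Cc1cccc(CCCCCC(=O)N2CCOC2=O)c1`. Its change from compound 3 is methyl in place of carbamoyl on an aromatic carbon. Among the compounds with values here, no measured step involves methyl; the steps that bear on it are the two carbamoyl steps above, read in reverse, which show that removing carbamoyl from this ring carbon in favour of a halogen gives a markedly lower number. A lower number is therefore expected for compound 4 in this assay, of a size comparable to those reversed steps rather than within the scatter. The estimate for compound 4 is 1500 nM, expected between 300 nM and 10000 nM. That estimate means an at least 13-fold lower number from compound 3 to compound 4 (1.12 log units; beyond the scatter).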

Compound 4, half-maximal inhibitory concentration: 350 nM
Beside the measured number, compound 4's estimate is 4.3-fold (0.63 log units) above it; low and high end bracket the measured number.
By their numbers in this assay, from the lowest: compounds 4 and 1 (each within the scatter of the next); then compound 2. At a limit, above all of these: compound 3.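

In this assay, methyl in place of carbamoyl gives an at least 57-fold lower number from compound 3 to compound 4 (1.75 log units; beyond the scatter), so a halogen is not required on this ring carbon for a number well clear of the limit. Methyl in place of bromo gives a 1.2-fold lower number from compound 1 to compound 4 (0.09 log units; within the scatter), leaving the two groups unresolved here, while methyl in place of iodo gives an 8.9-fold lower number from compound 2 to compound 4 (0.95 log units; beyond the scatter), so the two halogens do not behave as one class against methyl. Compound 3 is a limit of the assay and not a number, so its step to compound 4 gives only a bound: the limit of > 20000 nM in this assay, at which 1 of the 4 values shown sits.

Open, going by these compounds, is how other groups on this ring carbon would fall, such as chloro, ethyl or methoxy. Also open, on these data alone, is whether an amine or a carboxylic acid there would fare like carbamoyl, and whether a longer chain would preserve the match between methyl and bromo.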